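The compounds below may be only part of what the source reports. "The series", "measured", "known", "first", "only" and "open" are said of these compounds alone.

Measured compounds:
Compound 1 `CC1(c2ccccc2)CC(=O)N(CC(=O)N2CCN(c3ccccc3F)CC2)C1=O` — 100 mg/kg
Compound 2 `COc1cccc(N2CCN(C(=O)CN3C(=O)CC(C)(c4ccccc4)C3=O)CC2)c1` — 100 mg/kg
Compound 3 `CC1(c2ccccc2)CC(=O)N(CC(=O)N2CCN(c3ccccc3Cl)CC2)C1=O` — reported as not active, with no number

All three compounds share one core and differ only in the aryl group on the amine nitrogen in the ring. In a functional assay on the whole organism (strain CD-1) with Mus musculus as the target, with a stated time of 0.5 h (a higher number here means that more compound is needed for the effect, a lower number that less compound is needed), compound 1 gives 100 mg/kg and compound 2 gives 100 mg/kg; the step of no change at the digits printed from compound 1 to compound 2 (within the scatter) shows that exchanging one aryl group for another left the read-out where it was. As far as these compounds go, compound 3 stands apart: in this assay compound 3 is recorded as "not active" (no number reported), and no dose is attached to that finding, so its position on the number scale is unknown.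

Compound 4 `CC1(c2ccccc2)CC(=O)N(CC(=O)N2CCN(c3ccc(Cl)c(Cl)c3)CC2)C1=O` has not yet been tested. It differs from compound 3 in one place: 3,4-dichlorophenyl in place of 2-chlorophenyl on an amine nitrogen in a ring. For the measured compounds named here, no measured step covers this exact exchange, and the only step available, from compound 1 to compound 2, concerns other aryl groups and showed no change. Going by the values given here, the data therefore give no direction for the step from compound 3 to compound 4, and there is a fair chance that compound 4 is also reported without a number.

Compound 4 is expected to give about 100 mg/kg in this assay, with a range from 30 mg/kg to 300 mg/kg, if a number is reported at all.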

Compound 4, minimum effective dose: "not active" (no number reported)
The entry for compound 4 holds no number, and the estimate cannot be compared.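

In this assay, for the compounds shown here, compound 3 and compound 4 are both recorded as not active with no number, so no step between them can be read. Nothing available bears on why this is so. The compounds shown leave open whether compound 3 or compound 4 has any minimum effective dose on the number scale.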